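The source may hold more compounds than are shown below. What is called first, only, known or untested is meant among the compounds shown, and "the series" means these compounds.

Working notes, cytotoxicity series, an ADME assay on Vero cells (Chlorocebus sabaeus) for cytotoxicity, read by MTT assay, with a stated time of 72 h; on this read-out higher numbers stand for lower toxicity in this test and lower numbers for higher toxicity in this test

- compound 1 `C[C@]1(CN2CCc3nc(-c4ccc(OC(F)(F)F)cc4)ccc3C2)Cn2cc([N+](=O)[O-])nc2O1`: "not determined" (no result reported)
- compound 2 `C[C@]1(CN2CCc3nc(-c4ccccc4F)ccc3C2)Cn2cc([N+](=O)[O-])nc2O1`: > 32 ug/mL
- compound 3 `C[C@]1(CN2CCc3nc(-c4cccc(F)c4)ccc3C2)Cn2cc([N+](=O)[O-])nc2O1`: > 32 ug/mL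

Compound 3 gives only a limit of the assay in this assay, not a number. Compound 2 likewise gives only a limit. The step that the two limits leave unreadable from compound 2 to compound 3 is therefore unreadable. Compound 1 has no result in this assay.

Compound 4 `C[C@]1(CN2CCc3nc(-c4ccc(F)c(F)c4)ccc3C2)Cn2cc([N+](=O)[O-])nc2O1` differs from compound 3 by fluoro in place of hydrogen on an aromatic carbon. Among the compounds with values here, the one measured step bears on it only loosely, being unreadable; the relevant evidence is the limit of > 32 ug/mL in this assay, at which 2 of the 3 values shown sit. No step beyond the scatter is expected in this assay. Compound 4 is estimated at 40 ug/mL, range 16 ug/mL to 100 ug/mL, so the expected step is a step that the limit leaves unreadable from compound 3 to compound 4, most likely again reported as a limit.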

Compound 4, half-maximal cytotoxic concentration: > 32 ug/mL
Compound 4 was reported as a limit; the forecaster's own chance of this, stated with the estimate: 80%; the middle value is on the limit's open side.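

In this assay compound 4 gives only a limit, as do compound 2 and compound 3, so no step among these three compounds can be read: the limit of > 32 ug/mL in this assay, at which 3 of the 4 values shown sit.

The compounds shown leave open where any of them would give an actual half-maximal cytotoxic concentration, and whether the fluoro substitution changes it.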